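This account rests on a few compounds, and the source may have more. Where it says the series, first, only, none or still open, it means among the compounds named here.

The measured compounds and their values in an ADME assay on the whole organism for cytotoxicity, with Artemia salina as the target, with a stated time of 24 h; a lower number here means that less compound is needed, a higher number that more compound is needed for the effect:
compound 1 `Cc1ccc(S(=O)(=O)NC(=O)Nc2ccccc2C(=O)/C=C/c2ccc(F)cc2)cc1` gives 3.96 ug/mL;
compound 2 `Cc1ccc(S(=O)(=O)NC(=O)Nc2ccccc2C(=O)/C=C/c2ccc(Cl)cc2)cc1` gives 6.92 ug/mL;
compound 3 `Cc1ccc(S(=O)(=O)NC(=O)Nc2ccccc2C(=O)/C=C/c2ccc[nH]2)cc1` gives 32.1 ug/mL.

Compound 3 stands highest of the three: an 8.1-fold higher number from compound 1 to compound 3 (0.91 log units; beyond the scatter) and a 4.6-fold higher number from compound 2 to compound 3 (0.67 log units; beyond the scatter) are both beyond the scatter, while a 1.7-fold higher number from compound 1 to compound 2 (0.24 log units; within the scatter) is within it. Compound 4 `Cc1ccc(S(=O)(=O)NC(=O)Nc2ccccc2C(=O)/C=C/c2cccnc2)cc1` is compound 3 with one change: pyridin-3-yl in place of 1H-pyrrol-2-yl on a double-bonded chain carbon bound to a double-bonded chain carbon. Among the measured compounds shown here, no measured pair shows this exact exchange. The two steps that bear on it are those in which the 1H-pyrrol-2-yl group took the place of a six-membered aromatic ring, and both moved the number upward. A return to a six-membered aromatic ring, now pyridin-3-yl, is therefore expected to bring the number down, with less certainty than the measured steps carry, so a step of a 2.7-fold lower number from compound 3 to compound 4 (0.43 log units; beyond the scatter) is expected. Compound 4 is estimated at 12 ug/mL in this assay, with a range from 4 ug/mL to 35 ug/mL.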

Compound 4, concentration for half-maximal effect: 14.1 ug/mL
Estimate against measurement, compound 4: 1.2-fold (0.07 log units) below, and the stated range covers the measured number.
By their numbers in this assay, from the lowest: compounds 1 and 2 (each within the scatter of the next); then compound 4; then compound 3.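

In this assay, the six-membered pyridin-3-yl ring lowers the number relative to the five-membered 1H-pyrrol-2-yl ring (a 2.3-fold lower number from compound 3 to compound 4 (0.36 log units; beyond the scatter)), yet it does not match the halogen-bearing rings (a 2.0-fold higher number from compound 2 to compound 4 (0.31 log units; beyond the scatter); a 3.6-fold higher number from compound 1 to compound 4 (0.55 log units; beyond the scatter)). At this position, then, a six-membered aromatic ring alone does not bring the number down to the level of 4-chlorophenyl or 4-fluorophenyl. No measurement shown here explains these steps. Plain phenyl, without a halogen or ring nitrogen, is absent from these compounds, so the effects of removing the halogen and adding the ring nitrogen remain unseparated.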